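Replacing the 4-fluorophenyl of compound 2 with bromo

The source may hold more compounds than are shown below. What is called first, only, known or untested is meant among the compounds shown, and "the series" means these compounds.

Compound 1: 2.4 h
Compound 2: 1.28 h
Compound 3: 0.0833 h

The three measured compounds, compound 1 `COc1ccc(-c2cccc(S(=O)(=O)N3CCC(N4CCC(C)CC4)CC3)c2)cc1`, compound 2 `CC1CCN(C2CCN(S(=O)(=O)c3cccc(-c4ccc(F)cc4)c3)CC2)CC1` and compound 3 `CC1CCN(C2CCN(S(=O)(=O)c3cc(Br)cc4c3OCC4)CC2)CC1`, were tested in an ADME assay on S9 fraction from liver (Mus musculus, strain ICR/CD-1) for metabolic stability, read by LC-MS, using NADPH, with a stated time of 5 min, tested at 2 uM; a higher number here means that the compound lasts longer, a lower number that the compound disappears faster. Compound 2 gives 1.28 h, which lies within the scatter of compound 1 and clearly above compound 3. The next compound, compound 4 `CC1CCN(C2CCN(S(=O)(=O)c3cccc(Br)c3)CC2)CC1`, has not yet been measured. It differs from compound 2 by one change: bromo in place of 4-fluorophenyl on an aromatic carbon. The group is therefore exchanged on an aromatic carbon, meta to a large group.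

Among the compounds with values here, the only measured step is a 1.9-fold lower number from compound 1 to compound 2 (0.27 log units; within the scatter). That step is small, but it exchanges only fluoro for methoxy and leaves the aromatic ring in place, so it says little about removing 4-fluorophenyl altogether. Within the data shown here, the expectation leans instead on compound 3, the only measured compound carrying bromo, which gives 0.0833 h. A clear drop in this assay is therefore expected, though its size is uncertain. The expected change is a 3.2-fold lower number from compound 2 to compound 4 (0.51 log units; beyond the scatter). For compound 4 the estimated half-life is 0.4 h, with an expected range from 0.1 h to 1.3 h.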

Compound 4, half-life: 0.217 h
Compound 4: middle estimate off by 1.8-fold (0.27 log units), on the high side, and the stated range covers the measured number.
By their numbers in this assay, from the lowest: compound 3; then compound 4; then compounds 2 and 1 (each within the scatter of the next).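

In this assay, the exchange of 4-fluorophenyl for bromo on this aromatic carbon gives a 5.9-fold lower number from compound 2 to compound 4 (0.77 log units; beyond the scatter), and the exchange of 4-methoxyphenyl for bromo gives an 11-fold lower number from compound 1 to compound 4 (1.04 log units; beyond the scatter), whereas the earlier exchange of fluoro for methoxy on the outer ring stayed within the scatter. Among compounds 1, 2 and 4, the half-life therefore depends more on whether the aromatic ring is present at this place than on which of these two groups that ring carries, and none of the three goes against this. Nothing given here explains the fall in half-life.

The compounds shown leave open whether another group at this place, such as a cyclohexyl ring, a pyridine ring or a methyl, would hold the half-life as well. Going by these compounds, it also remains open how an amine or a carboxylic acid on the outer ring would change it.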